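The compounds below may be only part of what the source reports. "The series", "measured", "known", "first", "only" and "open" are said of these compounds alone.

Measured compounds: compound 1 `O=C1C(Nc2ccc(I)cc2)=CC(=O)c2c1nc1n2[C@H]2OC[C@@H](O)[C@H]2OC1` with 4010 nM; compound 2 `COc1ccc(NC2=CC(=O)c3nc4n(c3C2=O)[C@H]2OC[C@@H](O)[C@H]2OC4)cc1` with 4780 nM.

In a functional assay on HeLa cells (Homo sapiens) for inhibition, read by sulforhodamine B assay (a higher number here means a weaker inhibitor, a lower number a stronger inhibitor), compound 1 gives 4010 nM, the lowest of the two numbers shown, while compound 2 gives 4780 nM, a gap that lies within the usual scatter. Compound 3 `O=C1C(NC2CC2)=CC(=O)c2c1nc1n2[C@H]2OC[C@@H](O)[C@H]2OC1` differs from compound 1 in one place: cyclopropyl in place of 4-iodophenyl on an amine nitrogen. For the measured compounds named here, no measured pair shows this change, so its size is open from the data. A modest weakening is expected, small enough that it may stay inside the scatter. The expected step of a 1.6-fold higher number from compound 1 to compound 3 (0.21 log units; within the scatter) reflects that view. Compound 3 is estimated at 6500 nM, with a range from 2000 nM to 20000 nM.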

Compound 3, half-maximal inhibitory concentration: > 16000 nM
Compound 3: only a limit was reported; the forecaster's own chance of this, stated with the estimate: 15%; middle value at least 2.4-fold (0.39 log units) from the limit.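

In this assay, cyclopropyl in place of 4-iodophenyl on the amine nitrogen gives an at least 3.9-fold higher number from compound 1 to compound 3 (0.60 log units; beyond the scatter). For the compounds shown here, compound 1 and compound 2 both carry a substituted phenyl there, so only this change shows that the group on this nitrogen can move the number beyond the scatter. The value of compound 3 is a limit, not a number: the limit of > 16000 nM in this assay, at which 1 of the 3 values shown sits.

Going by these compounds, the full size of the step stays open. So does whether an unsubstituted phenyl, a benzyl or a longer alkyl chain on this nitrogen would keep the number of compound 1.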